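Swapping the aryl amine of a cyclic-carbamate bicycle

A few compounds are considered here, and "the series" means these few. Any claim that something is new, unique, unknown or untested is made for them only; others in the source may bear on it.

Compound 1 `CC1(OC(=O)N2CC3COCC(C2)C3Oc2ncnc(Oc3ccccc3F)c2F)CC1`: 136%
Compound 2 `CC1(OC(=O)N2CC3COCC(C2)C3Oc2ncnc(Nc3ccc(-n4cncn4)cc3F)c2F)CC1`: 83%

In a functional assay for agonist activity at Glucose-dependent insulinotropic receptor (Mus musculus), read by cAMP accumulation (on this read-out higher numbers stand for larger maximal responses and lower numbers for smaller maximal responses), compound 1 gives 136%, while compound 2 gives 83%, the lowest of the two numbers and a gap beyond the scatter. For the measured compounds named here, no step between a pair of measured compounds is on record, so only the two values themselves are available.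

Compound 3 `CC1(OC(=O)N2CC3COCC(C2)C3Oc2ncnc(Nc3cccnc3Cl)c2F)CC1` arises from compound 2 by a group of 7 heavy atoms (5 carbon, 1 nitrogen, 1 chlorine; one six-membered aromatic ring with 1 hetero atom) in place of a group of 12 heavy atoms (8 carbon, 3 nitrogen, 1 fluorine; one five-membered aromatic ring with 3 hetero atoms, one six-membered aromatic ring of carbon only), on a nitrogen on an aromatic ring. Since the change from compound 1 to compound 2 involved two places at once, nothing measured separates the effect of the amine from that of the aryl group. With a smaller aryl group entering, compound 3 is expected to land between the two measured values. The expected step is a number 17 percentage points higher from compound 2 to compound 3 (beyond the scatter), upward, and about at the edge of the scatter. Compound 3 is therefore estimated at 100%, within a range from 70% to 130%.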

Compound 3, largest response reached (reported as percent of maximum), in percent of the reference or control that the assay uses: 84%
Beside the measured number, compound 3's estimate is 16 percentage points above it; low and high end bracket the measured number.
By their numbers in this assay, from the lowest: compounds 2 and 3 (each within the scatter of the next); then compound 1.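

In this assay, the group on the nitrogen on an aromatic ring can be exchanged with little consequence. Replacing the larger two-ring group with 2-chloropyridin-3-yl gives a number 1 percentage points higher from compound 2 to compound 3 (within the scatter), so among these compounds the five-membered aromatic ring is not needed to keep the maximal response at this level. The step of a number 52 percentage points lower from compound 1 to compound 3 (beyond the scatter) shows that (2-chloropyridin-3-yl)amino in place of 2-fluorophenoxy on an aromatic carbon carries a large loss, and no supporting data explain either step.

As far as these compounds go, it remains open whether that loss belongs to the amine nitrogen or to the aryl group, a question that 2-fluorophenylamino or 2-chloropyridin-3-yloxy on the same aromatic carbon could settle. From the compounds shown here alone, how a simple alkylamine such as cyclopropylamine would behave at this position also remains open.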